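A few compounds are considered here, and "the series" means these few. Any claim that something is new, unique, unknown or untested is made for them only; others in the source may bear on it.

Among the measured compounds shown here, compound 2, `Cc1nc2c3ccccc3ccc2c2nc3c(ccc4ccccc43)c(-c3cc([N+](=O)[O-])ccc3N)c12`, gives the lowest of the three numbers measured so far in a functional assay on HCT-116 cells (Homo sapiens) for cytotoxicity, read by MTT assay, with a stated time of 48 h (on this read-out higher numbers stand for weaker inhibition and lower numbers for stronger inhibition), at 6010 nM. Compound 1, `Cc1nc2c3ccccc3ccc2c2nc3c(ccc4ccccc43)c(-c3cccc4ccccc34)c12`, gives 20800 nM in this assay, and compound 3, `Cc1ccc(-c2c3ccc4ccccc4c3nc3c2c(C)nc2c4ccccc4ccc32)cc1`, gives 67000 nM. The unmeasured compound 4, `Cc1nc2c3ccccc3ccc2c2nc3c(ccc4ccccc43)c(C)c12`, differs from compound 2 at one spot only: methyl in place of 2-amino-5-nitrophenyl on an aromatic carbon. Two measured steps change the same group on compound 2 and so bear on this one. With naphthalen-1-yl in that place the step was a 3.5-fold lower number from compound 1 to compound 2 (0.54 log units; beyond the scatter), so going the other way, towards the larger ring, raises the number. With 4-methylphenyl in that place the step was an 11-fold higher number from compound 2 to compound 3 (1.05 log units; beyond the scatter), a clearly larger rise, and a 3.2-fold higher number from compound 1 to compound 3 (0.51 log units; beyond the scatter) fits the same ordering. Both replacements gave higher numbers, and the smaller of the two gave the higher number. A methyl is smaller still, so an upward step beyond the scatter is expected. The number for compound 4 is estimated at 45000 nM, with a range from 12000 nM to 160000 nM. That estimate means an expected step of a 7.5-fold higher number from compound 2 to compound 4 (0.87 log units; beyond the scatter).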

Compound 4, half-maximal inhibitory concentration: > 80000 nM
Compound 4: no number, only a limit (the forecaster's own chance of this, stated with the estimate: 25%); middle value at least 1.7-fold (0.24 log units) from the limit.
By their numbers in this assay, from the lowest: compound 2; then compound 1; then compound 3. At a limit, above all of these: compound 4.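

Compound 4 gives no number, only a limit of the assay: the limit of > 80000 nM in this assay, at which 1 of the 4 values shown sits. Even so, the limit is enough to show that methyl, a single carbon with no ring, on this aromatic carbon opposite the ring nitrogen, gives an at least 13-fold higher number from compound 2 to compound 4 (1.12 log units; beyond the scatter) and an at least 3.8-fold higher number from compound 1 to compound 4 (0.58 log units; beyond the scatter), so the ring-bearing groups of these two compounds cannot be cut back to methyl without losing cytotoxicity. The comparison with 4-methylphenyl stays unsettled, with an at least 1.1-fold higher number from compound 3 to compound 4 (0.07 log units; that floor lies within the scatter), a floor that lies within the scatter.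

The compounds shown leave open how a plain phenyl ring or a longer chain such as propyl would behave at this place. They also leave open whether the amine or the nitro group on the ring of compound 2 goes with its lower number.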